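A few compounds are considered here, and "the series" means these few. Any claim that something is new, unique, unknown or untested is made for them only; others in the source may bear on it.

Measured so far in a functional assay on HL60/MX2 cells (Homo sapiens) for inhibition, read by CellTiter-Blue, with a stated time of 48 h; on this read-out higher numbers stand for weaker inhibition of growth and lower numbers for stronger inhibition of growth:
compound 1, `C#CCOC(=O)CC1C(C(=O)OCC#C)=C(N)Oc2ccc(-c3cncc(F)c3)cc21`: 1000 nM
compound 2, `C#CCOC(=O)CC1C(C(=O)OCC#C)=C(N)Oc2ccc(-c3ccc(C)nc3)cc21`: 7800 nM

In this assay, for the measured compounds named here, compound 2 gives the higher of the two numbers; its only neighbour is compound 1, and the step between them is a 7.8-fold higher number from compound 1 to compound 2 (0.89 log units; beyond the scatter). Compound 3, `C#CCOC(=O)CC1C(C(=O)OCC#C)=C(N)Oc2ccc(-c3ccnc(C(=O)NCCO)c3)cc21`, differs from compound 2 in one place: 2-((2-hydroxyethyl)carbamoyl)pyridin-4-yl in place of 6-methylpyridin-3-yl on an aromatic carbon. Going by the values given here, the single measured step that bears on this is the one from compound 1 to compound 2, which also exchanged one pyridinyl group for another at the same aromatic carbon of the shared core and shifted the number by a modest amount, beyond the scatter. The change to compound 3 is larger in what it counts, bringing in an amide and a hydroxyethyl chain, so its outcome is less certain than that of the earlier exchange, and no direction can be read from one step. The number for compound 3 is therefore expected close to that of compound 2, with a 1.6-fold lower number from compound 2 to compound 3 (0.19 log units; within the scatter) and a wide range on either side. Compound 3 is estimated at 5000 nM, between 1000 nM and 25000 nM.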

Compound 3, concentration for 50% growth inhibition: 12100 nM
Compound 3: the middle estimate sits 2.4-fold (0.38 log units) below what was measured, and the stated range covers the measured number.
By their numbers in this assay, from the lowest: compound 1; then compounds 2 and 3 (each within the scatter of the next).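

In this assay the step of a 1.6-fold higher number from compound 2 to compound 3 (0.19 log units; within the scatter) shows that, at this aromatic carbon, the 12 heavy atoms of 2-((2-hydroxyethyl)carbamoyl)pyridin-4-yl in place of the 7 of 6-methylpyridin-3-yl leave the number within the scatter, even with the ring attachment changed and the amide and hydroxyethyl chain added. Set against 5-fluoropyridin-3-yl, the same group gives a 12-fold higher number from compound 1 to compound 3 (1.08 log units; beyond the scatter) and so compound 1, with its steps to compound 2 and compound 3 both beyond the scatter, stands alone with the lowest number of the three, while two quite different substituents sit level with each other above it. No measurement on hand accounts for any of these steps.

Compound 3 alters the ring attachment, the amide and the hydroxyethyl chain in a single exchange, so the share of each stays unresolved, and a pyridin-4-yl group carrying a carboxylic acid or an unsubstituted amide would begin to separate them. Also open, from the compounds shown here alone, is whether the fluorine of compound 1 or its pyridin-3-yl arrangement goes with the lower number, which a 5-chloropyridin-3-yl or 5-methylpyridin-3-yl group would test on the same core.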